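The source may report more compounds than this note shows. Statements on the series, on what has been measured and on what is new or still open speak of the compounds shown alone.

Compound 1 `CCCCc1ccc(NS(=O)(=O)c2ccc(N3CCNC3=O)cc2)cc1`: 450 nM
Compound 2 `CCCCCCCc1ccc(NS(=O)(=O)c2ccc(N3CCNC3=O)cc2)cc1`: > 1000 nM (a limit of the assay)

In a functional assay on M21 cells (Homo sapiens) for antiproliferative activity, read by sulforhodamine B assay, with a stated time of 48 h (a lower number here means a stronger inhibitor, a higher number a weaker inhibitor), compound 1 gives 450 nM. Compound 2 has no number, only a limit, > 1000 nM. Compound 3 `CC(C)(C)c1ccc(NS(=O)(=O)c2ccc(N3CCNC3=O)cc2)cc1` carries tert-butyl in place of heptyl on an aromatic carbon.

For the measured compounds named here, one measured step bears on this change: an at least 2.2-fold higher number from compound 1 to compound 2 (0.34 log units; beyond the scatter). That step puts propyl on a saturated chain carbon, four bonds along the chain from an aromatic carbon, and the number rises. Compound 3 drops much of that heptyl chain, so the change is expected to run the other way in this assay, by a size similar to that step or somewhat more. Going by the values given here, this rests on the single step to compound 2, which is itself bounded only by a limit. The expected change is an at least 2.0-fold lower number from compound 2 to compound 3 (0.30 log units; that floor lies within the scatter). For compound 3 the estimated value is 500 nM, with an expected range of 170 nM to 1400 nM.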

Compound 3, half-maximal inhibitory concentration: > 1000 nM
Compound 3 was reported as a limit; the forecaster's own chance of this, stated with the estimate: 20%; middle value at least 2.0-fold (0.30 log units) from the limit.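

In this assay compound 3 is reported only as a limit, > 1000 nM. On this aromatic carbon, tert-butyl in place of butyl gives an at least 2.2-fold higher number from compound 1 to compound 3 (0.34 log units; beyond the scatter), so among the groups shown here the branched group does not keep the activity of the straight butyl chain. The step between heptyl and tert-butyl cannot be read, and the comparison between those two groups ends at the same limit: the limit of > 1000 nM in this assay, at which 2 of the 3 values shown sit.

For the compounds shown here, whether compound 2 and compound 3 differ at all stays open, and butyl remains the only group here with a measured number in this assay. From the compounds shown here alone, how an ethyl or a pentyl chain, a cyclopentyl ring, or an amine or carboxylic acid on the end of the chain would fare at this position also remains open.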